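The compounds below may be only part of what the source reports. "The series", "measured", "known", "first", "only" and "open" are said of these compounds alone.

Going by the values given here, compound 2 `COc1cc(-c2cc(/C=C/C(=O)c3ccc(Cl)c(Cl)c3)[nH]n2)cc(OC)c1OC` is one of only two compounds that have so far been tested in a functional assay on NCI-H226 cells (Homo sapiens) for cytotoxicity, read by sulforhodamine B assay, with a stated time of 48 h, tested at 0.01 uM; on this read-out lower numbers stand for a stronger effect and higher numbers for a weaker effect at the one concentration tested. In this assay compound 2 gives 103%, the higher of the two numbers, so at the single concentration tested its effect is the weaker of the pair. Compound 1 `COc1cc(-c2cc(/C=C/C(=O)c3ccc(N)cc3)[nH]n2)cc(OC)c1OC` carries a 4-aminophenyl group on the carbonyl carbon instead, and in this assay compound 1 gives 92%. Among the compounds with values here, the one step between them, a number 11 percentage points higher from compound 1 to compound 2 (beyond the scatter), is the only change at this position that has been measured, and it is modest.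

Compound 3 `COc1ccc(C(=O)/C=C/c2cc(-c3cc(OC)c(OC)c(OC)c3)n[nH]2)cc1OC` has not yet been measured. It differs from compound 2 in a single place: 3,4-dimethoxyphenyl in place of 3,4-dichlorophenyl on a carbonyl carbon. Within the data shown here, no measured step swaps these two groups, so the direction of any change is uncertain; the only comparable step, at the same carbonyl carbon but with different groups, moved the number by a modest amount. The step of a number 7 percentage points lower from compound 2 to compound 3 (within the scatter) is therefore expected to be small, most likely a slight shift back towards the lower number seen for compound 1. Compound 3 is estimated to give 96% in this assay, with a range from 82% to 110%.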

Compound 3, a percentage reported as activity, at one concentration (the size of the read-out at that concentration, not a potency): 98%
The estimate for compound 3 lay 2 percentage points below the measured number; the range from low to high includes it.
By their numbers in this assay, from the lowest: compounds 1, 3 and 2 (each within the scatter of the next, the first and the last beyond it).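

A group with 2 hydrogen-bond acceptors replaces one with 0 on the carbonyl carbon, and the step of a number 5 percentage points lower from compound 2 to compound 3 (within the scatter) shows that in this assay this exchange cannot be told apart from no change at all. The step of a number 6 percentage points higher from compound 1 to compound 3 (within the scatter) is also small enough to be read as no change, so compound 3 cannot be grouped with either earlier compound, and the gap between compound 1 and compound 2 remains the only separation seen at this position. No measurement at hand gives a reason for any of these numbers.

All three compounds shown carry a substituted phenyl ring on the carbonyl carbon, so it remains open whether a different kind of group there, such as a carboxylic acid or a longer alkyl chain, would move the number by more than the usual scatter. From the compounds shown here alone, with only one concentration to go on, it also remains open whether these three compounds would separate more clearly at other concentrations.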